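Ring-opened thiourea analog in the cytotoxicity series

The compounds below may be only part of what the source reports. "The series", "measured", "known", "first", "only" and "open" are said of these compounds alone.

Compound 1, `O=C(N/N=C1\C(=O)Nc2ccccc21)Nc1ccccc1`, and compound 2, `O=C1Nc2ccccc2/C1=N/NC(=S)N1CCCCC1`, share one core and differ only in the side arm on the carbonyl or thiocarbonyl carbon. In an ADME assay on RD cells (Homo sapiens) for cytotoxicity (a higher number here means that more compound is tolerated, a lower number that less compound is tolerated), compound 1 gives > 25000 nM, which is a limit of the assay and not a number. In this assay compound 2 likewise gives > 25000 nM, again a limit rather than a number. Among the compounds with values here, compound 2 therefore stands at the edge of what the assay reports, and the only other value shown sits at the same place, as the limit of > 25000 nM in this assay, at which 2 of the 2 values shown sit, records, so nothing measured so far separates the two.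

Compound 3, `CCN(CC)C(=S)N/N=C1\C(=O)Nc2ccccc21`, is yet to be measured in this assay. It differs from compound 2 by diethylamino in place of piperidin-1-yl on a thiocarbonyl carbon. Within the data shown here, no measured step between two compounds is available to calibrate a change of this kind. As compound 2 gives > 25000 nM, a limit, the expected step is a step that the limit leaves unreadable from compound 2 to compound 3, none beyond the usual scatter, with the assay likely to report a limit once more. Compound 3 is estimated at 30000 nM in this assay, within 15000 nM to 60000 nM.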

Compound 3, half-maximal cytotoxic concentration: > 25000 nM
Compound 3: only a limit was reported; the forecaster's own chance of this, stated with the estimate: 80%; the middle value is on the limit's open side.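

In this assay compound 3 gives > 25000 nM, a limit and not a number. With compound 2 also at a limit, no step can be read between compound 2 and compound 3: the limit of > 25000 nM in this assay, at which 3 of the 3 values shown sit.

The compounds shown leave open whether any change in the side arm on the shared core brings the half-maximal cytotoxic concentration to a readable value.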